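The source may report more compounds than this note shows. Statements on the series, on what has been measured and on what is new or still open speak of the compounds shown alone.

Working notes on the series. In an assay on HEK293 cells for displacement of a labelled ligand from growth hormone secretagogue receptor type 1 (Homo sapiens), with a stated time of 60 min (a lower number here means a stronger inhibitor, a higher number a weaker inhibitor), compound 1 `COc1ccc(-n2cc3nc(-c4cccnc4C)n(C[C@H]4CCCN(C[C@H]5CCCO5)C4)c(=O)c3n2)cc1` gives 52 nM. Among the compounds with values here, compound 2 `Cc1ncccc1-c1nc2cn(-c3cccc(OC(C)C)c3)nc2c(=O)n1C[C@H]1CCCN(C[C@H]2CCCO2)C1` gives 11 nM in this assay, and the one single-point step measured so far, a 4.7-fold lower number from compound 1 to compound 2 (0.67 log units; beyond the scatter), concerns the aryl group on the aromatic nitrogen. Compound 3 `COc1cccc(-n2cc3nc(-c4cccnc4C)n(C[C@H]4CCCN(CC5CCC5)C4)c(=O)c3n2)c1` gives 1.6 nM in this assay, the lowest of the three numbers, with its gaps to compound 2 and to compound 1 both beyond the scatter. Within the data shown here, compound 3 differs from compound 2 in two places at once, so their values can only be set side by side; no single step between them is available.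

Compound 4 `COc1cccc(-n2cc3nc(-c4cccnc4C)n(C[C@H]4CCCN(CC5CCCC5)C4)c(=O)c3n2)c1` differs from compound 3 by cyclopentyl in place of cyclobutyl on a saturated chain carbon bound to an amine nitrogen in a ring. Among the measured compounds shown here, none of the measured steps bears on this position: the only step in hand sits on the aryl group on the aromatic nitrogen, and the substituent on the ring amine nitrogen has not yet been varied alone anywhere. With nothing to set a direction, no step beyond the scatter is expected in this assay, and the estimated change is a 1.3-fold higher number from compound 3 to compound 4 (0.10 log units; within the scatter). Compound 4 is therefore expected to give about 2 nM, with a range from 0.6 nM to 7 nM.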

Compound 4, half-maximal inhibitory concentration: 12 nM
Compound 4: middle estimate off by 6.0-fold (0.78 log units), on the low side; the whole stated range lies below it.
By their numbers in this assay, from the lowest: compound 3; then compounds 2 and 4 (each within the scatter of the next); then compound 1.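

Within the data shown here, the change of cyclobutyl to cyclopentyl on a saturated chain carbon bound to an amine nitrogen in a ring gives a 7.5-fold higher number from compound 3 to compound 4 (0.88 log units; beyond the scatter) in this assay, and this is the first step read at this position alone. It shows that the substituent on the ring amine nitrogen is not a neutral place in this assay: with everything else held constant, going from cyclobutylmethyl to cyclopentylmethyl moves the number beyond the scatter, towards a weaker inhibitor. The size of this step also shows that a change from a four-membered to a five-membered ring of carbon only can matter here, but nothing measured on these compounds accounts for it.

As far as these compounds go, with only these two ring sizes read alone, it remains open whether cyclopropylmethyl, cyclohexylmethyl or an open chain such as isobutyl on the same nitrogen would continue this direction or break it. From the compounds shown here alone, it is also open whether the step keeps its size when the aryl group on the aromatic nitrogen is 3-isopropoxyphenyl rather than the group shared by compound 3 and compound 4.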